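The source may hold more compounds than are shown below. What is called first, only, known or untested is meant among the compounds shown, and "the series" means these compounds.

Measured so far in an ADME assay (liver) for metabolic stability, with Liver microsome (Rattus norvegicus) as the target, using microsomes and NADPH, with a stated time of 30 min; a lower number here means slower removal, a higher number faster removal of the compound:

- compound 1 `C#CCC(O)(c1ccc(N2CCN(S(=O)(=O)c3ccc(N)nc3)C[C@@H]2C#CC)cc1)C(F)(F)F`: 59 mL.min-1.g-1
- compound 2 `CC#C[C@H]1CN(S(=O)(=O)c2ccc(N)nc2)CCN1c1ccc(S(=N)(=O)C2CC2)cc1`: 23 mL.min-1.g-1
- compound 3 `CC#C[C@H]1CN(S(=O)(=O)c2ccc(N)nc2)CCN1c1ccc(C(=O)NC)cc1`: 41 mL.min-1.g-1

Compound 1 gives the highest number of the three. Its nearest neighbour is compound 3, and the step of a 1.4-fold lower number from compound 1 to compound 3 (0.16 log units; within the scatter) stays within the scatter, so the two cannot be ordered. Compound 2 sits furthest away: the step of a 2.6-fold lower number from compound 1 to compound 2 (0.41 log units; beyond the scatter) is beyond the scatter, a modest move to slower removal. Between the two smaller groups the step of a 1.8-fold higher number from compound 2 to compound 3 (0.25 log units; within the scatter) is within the scatter.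

The next compound is compound 4 `CC#C[C@H]1CN(S(=O)(=O)c2ccc(N)nc2)CCN1c1ccc([S+](C)[O-])cc1`. Relative to compound 1 the change is a group of 3 heavy atoms (1 carbon, 1 oxygen, 1 sulfur; no ring) in place of a group of 9 heavy atoms (5 carbon, 1 oxygen, 3 fluorine; no ring), on an aromatic carbon. Both measured steps from compound 1 bear on this: each replaces the same nine-atom group on the same aromatic carbon with a smaller group carrying a hydrogen-bond acceptor, and in this assay the numbers moved down, modestly for compound 2 and within the scatter for compound 3. For compound 4 a step of comparable size, downward, is therefore expected, closer to the step to compound 2 than to no change, though a result within the scatter of compound 1 cannot be ruled out. The expected step is a 2.0-fold lower number from compound 1 to compound 4 (0.29 log units; within the scatter). Compound 4 is estimated at 30 mL.min-1.g-1, with a range of 15 mL.min-1.g-1 to 60 mL.min-1.g-1.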

Compound 4, intrinsic clearance in microsomes: 17 mL.min-1.g-1
For compound 4 the middle estimate is 1.8-fold (0.25 log units) above the measured one, within the range that was stated.
By their numbers in this assay, from the lowest: compounds 4, 2, 3 and 1 (each within the scatter of the next, the first and the last beyond it).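

In this assay, a 3.5-fold lower number from compound 1 to compound 4 (0.54 log units; beyond the scatter) makes this the second replacement of the nine-atom group, on this aromatic carbon para to a large group, to give a step beyond the scatter; compound 2 is the other, while compound 3 goes against any general drop, as its step from compound 1 stays within the scatter. Going by these compounds alone, the three-atom group also separates from the four-atom group, with a 2.4-fold lower number from compound 3 to compound 4 (0.38 log units; beyond the scatter), which the earlier compounds could not show for any pair of the smaller groups, whereas a 1.4-fold lower number from compound 2 to compound 4 (0.13 log units; within the scatter) leaves the two sulfur-bearing groups unordered, so the numbers do not simply follow the heavy-atom count of the group that enters. No measurement is available here that accounts for these differences.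

The compounds shown leave open whether a sulfur-bearing group is what matters at this position, since only compounds 2 and 4 carry one and compound 3 cannot be ordered against compound 2. A sulfone, a nitrile or a carboxylic acid on the same aromatic carbon would test how far the number follows the entering group, and whether it can fall further.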